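The compounds below may be only part of what the source reports. "The series", "measured", "known", "first", "only" and "open" are said of these compounds alone.

Compound 1 `C=CC(=O)Nc1cc2c(Nc3ccc(OCc4cccc(F)c4)c(Cl)c3)ncnc2cc1OCc1cn(CCCC(=O)NO)nn1`: > 25000 nM
Compound 2 `C=CC(=O)Nc1cc2c(Nc3ccc(OCc4cccc(F)c4)c(Cl)c3)ncnc2cc1OCc1cn(CCCCC(=O)NO)nn1`: > 25000 nM
Compound 3 `C=CC(=O)Nc1cc2c(Nc3ccc(F)c(Cl)c3)ncnc2cc1OCc1cn(CCC(=O)NO)nn1`: > 25000 nM

In an ADME assay on L02 cells (Homo sapiens) for cytotoxicity, read by MTT assay, with a stated time of 72 h (a higher number here means a weaker inhibitor, a lower number a stronger inhibitor), compound 3 gives > 25000 nM, which is a limit of the assay and not a number. Within the data shown here, the measurements so far offer only one reading: the limit of > 25000 nM in this assay, at which 3 of the 3 values shown sit. Compound 3 therefore has no exact place among the measured compounds.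

Compound 4 `C=CC(=O)Nc1cc2c(Nc3ccc(F)c(Cl)c3)ncnc2cc1OCc1cn(CCCC(=O)NO)nn1` has not yet been measured. Its difference from compound 3 is (hydroxycarbamoyl)methyl in place of hydroxycarbamoyl on a saturated chain carbon, two bonds along the chain from an aromatic nitrogen. In words, (hydroxycarbamoyl)methyl stands in place of hydroxycarbamoyl on a saturated chain carbon, two bonds along the chain from an aromatic nitrogen, so 2-(hydroxycarbamoyl)ethyl becomes 3-(hydroxycarbamoyl)propyl.

The closest measured comparison is a step that the two limits leave unreadable from compound 1 to compound 2. It makes the same kind of exchange, but three bonds along the chain from an aromatic nitrogen, and its size cannot be read. It therefore gives no sign that such a change moves the result in either direction, and no step beyond the usual scatter is expected. The expected change is a step that the limit leaves unreadable from compound 3 to compound 4. Compound 4 will most likely also be reported only as a limit. For compound 4 the estimated value is 32000 nM, with an expected range from 14000 nM to 70000 nM.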

Compound 4, half-maximal inhibitory concentration: > 25000 nM
Compound 4: a limit, no number; the forecaster's own chance of this, stated with the estimate: 85%; the middle value lies beyond the limit too.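

Compound 4 is reported only as a limit, so neither its step from compound 3 nor its step from compound 1 can be read. All the results shown stand at one reading: the limit of > 25000 nM in this assay, at which 4 of the 4 values shown sit. The compounds leave open what the exact values in this assay are, and whether either exchange changes them.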